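Dichlorophenyl Urea on the Shared Core: Expected Activity

A few compounds are considered here, and "the series" means these few. Any claim that something is new, unique, unknown or untested is made for them only; others in the source may bear on it.

Three compounds with the same core and a urea linking to a variable phenyl ring have been measured in a functional assay on UACC-257 cells (Homo sapiens) for inhibition, read by sulforhodamine B assay, with a stated time of 48 h, tested at 10 uM; a lower number here means a stronger effect, a higher number a weaker effect of the compound at the concentration tested. Compound 1, `COc1cc2cc(Oc3ccc(NC(=O)Nc4ccc(C)cc4)cc3)c(C)nc2cc1OC`, gives 112% in this assay, the highest of the three numbers. Compound 2, `COc1cc2cc(Oc3ccc(NC(=O)Nc4ccc(C(F)(F)F)cc4)cc3)c(C)nc2cc1OC`, gives 66.5%, and compound 3, `COc1cc2cc(Oc3ccc(NC(=O)Nc4cccc(C(F)(F)F)c4)cc3)c(C)nc2cc1OC`, gives -14.5%. Moving from compound 1 to compound 2 means trifluoromethyl in place of methyl on an aromatic carbon, and the result is a number 45.5 percentage points lower from compound 1 to compound 2 (beyond the scatter). Moving from compound 1 to compound 3 means 3-(trifluoromethyl)phenyl in place of 4-methylphenyl on an amide-type nitrogen, giving a number 126.5 percentage points lower from compound 1 to compound 3 (beyond the scatter).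

Compound 4, `COc1cc2cc(Oc3ccc(NC(=O)Nc4ccc(Cl)c(Cl)c4)cc3)c(C)nc2cc1OC`, has not yet been measured. Its difference from compound 1 is 3,4-dichlorophenyl in place of 4-methylphenyl on an amide-type nitrogen. Both measured steps away from compound 1 replace the 4-methylphenyl with a different substituted phenyl and both lower the number by a large margin, so a large drop in this assay is expected here as well. The expected step is a number 92 percentage points lower from compound 1 to compound 4 (beyond the scatter). Compound 4 is therefore estimated at 20%, with a likely range from -20% to 70%.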

Compound 4, a percentage reported as activity, at one concentration (the size of the read-out at that concentration, not a potency): 1.38%
The estimate for compound 4 lay 18.6 percentage points above the measured number, within the range that was stated.
By their numbers in this assay, from the lowest: compound 3; then compound 4; then compound 2; then compound 1.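

In this assay, 3,4-dichlorophenyl on the amide-type nitrogen gives a number 110.6 percentage points lower from compound 1 to compound 4 (beyond the scatter), so a large drop does not depend on a trifluoromethyl group, which both earlier replacements carried. The comparison with the single-substituent 4-(trifluoromethyl)phenyl group gives a number 65.1 percentage points lower from compound 2 to compound 4 (beyond the scatter), and the comparison with 3-(trifluoromethyl)phenyl gives a number 15.9 percentage points higher from compound 3 to compound 4 (beyond the scatter), a modest step that leaves compound 3 with the lowest number. Among these four compounds, the two groups with a 3 in their names, in compound 3 and compound 4, give lower numbers than the two groups named only with a 4, in compound 1 and compound 2, although four compounds are too few to establish this as a rule.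

No measurement shown here explains why these groups differ. The compounds also leave open which chlorine in compound 4 matters, since neither 3-chlorophenyl nor 4-chlorophenyl appears among them, and whether a methoxy group or an amine on the same phenyl ring would give a similarly low number.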